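Chloro-for-hydrogen step on the shared purine-free core

The compounds below may be only part of what the source reports. "The series", "measured", "known", "first", "only" and "open" are said of these compounds alone.

Two compounds of this series carry a number in a functional assay on KM12 cells (Homo sapiens) for cytotoxicity, read by sulforhodamine B assay, with a stated time of 48 h; a higher number here means a weaker inhibitor of growth, a lower number a stronger inhibitor of growth. Compound 1 `ClCc1ccccc1Cn1cnc2c(Cl)ncnc21` gives 16600 nM in this assay. Compound 2 `ClCc1cccc(Cn2cnc3c(Cl)ncnc32)c1` gives 3460 nM in this assay, the lower of the two numbers; the gap to compound 1 lies beyond the scatter. For the measured compounds named here, no step between these two compounds is computed, so only the two values stand side by side, and compound 2 is the stronger inhibitor of growth of the pair.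

Compound 3 `ClCc1cccc(Cn2cnc3c(Cl)nc(Cl)nc32)c1` has not yet been measured in this assay. It differs from compound 2 in one place: chloro in place of hydrogen on an aromatic carbon. Going by the values given here, nothing measured reports a change at this position, so no computed step guides the expectation. The change is small in count, and the expected step is a 1.4-fold lower number from compound 2 to compound 3 (0.14 log units; within the scatter), with direction uncertain and most likely not beyond the scatter. For compound 3 the estimate in this assay is 2500 nM, with a range expected from 800 nM to 9000 nM.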

Compound 3, concentration for 50% growth inhibition: 1820 nM
Beside the measured number, compound 3's estimate is 1.4-fold (0.14 log units) above it; the measured number falls inside the stated range.
By their numbers in this assay, from the lowest: compounds 3 and 2 (each within the scatter of the next); then compound 1.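

For the compounds shown here, the first step at this position, on an aromatic carbon between two ring nitrogen atoms, is chloro in place of hydrogen: in this assay it gives a 1.9-fold lower number from compound 2 to compound 3 (0.28 log units; within the scatter). The step does not separate the two compounds, so on this evidence one added chlorine atom at this carbon is accommodated with the growth-inhibition read-out staying within the scatter, and the position does not yet show itself as one that moves the number in either direction. No supporting data bear on why the step is this size, and nothing shown explains it.

The compounds shown carry only hydrogen or chloro at this carbon, so it remains open whether a larger or different group there, such as an amine or a methoxy group, would give a step beyond the scatter. As far as these compounds go, it also remains open whether chloro in place of hydrogen at this carbon would give a step of similar size on the core of compound 1, where the chloromethyl group sits elsewhere on the benzene ring.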